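Imidazole in Place of Tetrazolylmethyl on a Fluoronaphthyl Pyridinone

The compounds below may be only part of what the source reports. "The series", "measured", "known", "first", "only" and "open" are said of these compounds alone.

Going by the values given here, compound 2 `CC(C)C(Cc1nnn[nH]1)c1ccc(-c2ccc3cccc(F)c3c2)[nH]c1=O` is the weaker of the two compounds measured so far: in an assay on CHO cells for displacement of a labelled ligand from prostaglandin E2 receptor EP3 subtype (Homo sapiens), read by radioligand binding (a higher number here means a weaker inhibitor, a lower number a stronger inhibitor), compound 2 gives 34 nM, whereas compound 1 `Cc1nc(C(c2ccc(-c3ccc4cccc(F)c4c3)[nH]c2=O)C(C)C)[nH]c1C` gives 7 nM. Among the compounds with values here, the only step measured, a 4.9-fold higher number from compound 1 to compound 2 (0.69 log units; beyond the scatter), replaced a directly attached 4,5-dimethyl-1H-imidazol-2-yl with (1H-tetrazol-5-yl)methyl. Compound 3 `Cc1c[nH]c(C(c2ccc(-c3ccc4cccc(F)c4c3)[nH]c2=O)C(C)C)n1` reverses most of that change: 4-methyl-1H-imidazol-2-yl in place of (1H-tetrazol-5-yl)methyl on a saturated chain carbon bound to an aromatic carbon and a saturated chain carbon. The group entering differs from that of compound 1 only by lacking one methyl, so the step from compound 2 to compound 3 is expected to run opposite to the measured step and to be of similar size, giving a lower number beyond the scatter, about a 3.4-fold lower number from compound 2 to compound 3 (0.53 log units; beyond the scatter). Compound 3 is therefore estimated in this assay at 10 nM, with a range from 4 nM to 25 nM.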

Compound 3, inhibition constant: 12 nM
Estimate against measurement, compound 3: 1.2-fold (0.08 log units) below, and the stated range covers the measured number.
By their numbers in this assay, from the lowest: compounds 1 and 3 (each within the scatter of the next); then compound 2.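

Replacing (1H-tetrazol-5-yl)methyl with 4-methyl-1H-imidazol-2-yl on this saturated chain carbon gives a 2.8-fold lower number from compound 2 to compound 3 (0.45 log units; beyond the scatter), so a lower number in this assay does not require the dimethylimidazole of compound 1. Placing hydrogen for methyl on an aromatic carbon of that imidazole gives a 1.7-fold higher number from compound 1 to compound 3 (0.23 log units; within the scatter), which shows that the second methyl makes no difference that can be told from the scatter at this position. No measurement bearing on why these numbers differ is available.

The compounds shown leave open how an imidazol-2-yl carrying no methyl, or a carboxylic acid on the same carbon, would read in this assay. They also do not separate the ring from its linking methylene in the step from tetrazole to imidazole, a question that a directly attached 1H-tetrazol-5-yl would address.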